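The compounds below may be only part of what the source reports. "The series", "measured", "known", "first", "only" and "open" are said of these compounds alone.

Measured compounds:
- compound 1, `Cc1cc(O)cc(-c2nn(CC#N)cc2-c2ccnc(-c3ccc(Oc4ccccc4)cc3)c2)c1`: 1800 nM
- compound 2, `COc1cc(C)cc(-c2nn(CC#N)cc2-c2ccnc(-c3ccc(N(C)C)cc3)c2)c1`: 345 nM

In a functional assay on CAKI-1 cells (Homo sapiens) for inhibition, read by sulforhodamine B assay, with a stated time of 48 h (on this read-out higher numbers stand for weaker inhibition of growth and lower numbers for stronger inhibition of growth), compound 2 gives 345 nM, the lowest of the two numbers. Its nearest neighbour, compound 1, gives 1800 nM in this assay, a gap beyond the scatter. Among the measured compounds shown here, no step between measured compounds differing in one place is available, so the effect of the change to be tested has no direct precedent.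

Compound 3, `Cc1cc(O)cc(-c2nn(CC#N)cc2-c2ccnc(-c3ccc(N(C)C)cc3)c2)c1`, differs from compound 2 by hydrogen in place of methyl on an oxygen on an aromatic ring. Compound 1 carries the same hydroxy group but also a different aryl substituent, so its value shows only the combined outcome. For compound 3 a small step, possibly toward a higher number, is expected in this assay, within or near the scatter: a 1.4-fold higher number from compound 2 to compound 3 (0.16 log units; within the scatter). The estimate for compound 3 is 500 nM, with a range from 150 nM to 1600 nM.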

Compound 3, concentration for 50% growth inhibition: 2890 nM
Estimate against measurement, compound 3: 5.8-fold (0.76 log units) below, outside the stated range (above it).
By their numbers in this assay, from the lowest: compound 2; then compounds 1 and 3 (each within the scatter of the next).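

In this assay the change from methoxy to hydroxy on the 3-methoxy-5-methylphenyl group, with dimethylamino held, gives an 8.4-fold higher number from compound 2 to compound 3 (0.92 log units; beyond the scatter) and shows that the methyl on this oxygen matters within this pair. With the hydroxy group held, dimethylamino in place of phenoxy gives a 1.6-fold higher number from compound 1 to compound 3 (0.21 log units; within the scatter) and so shows no readable effect of that exchange on this read-out. No measurement at hand speaks to the reason for the large step at the oxygen.

On these data alone, whether methoxy to hydroxy has the same size when phenoxy replaces dimethylamino stays open. Also open, as far as these compounds go, is how a longer ether such as ethoxy, or an amine in place of the oxygen, would stand against compound 2 in this assay and whether the step holds in other cell lines.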